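The source may report more compounds than this note shows. Statements on the series, on what has been measured and on what is new or still open speak of the compounds shown alone.

Measured compounds:
- Compound 1, `Clc1ccc(-c2[nH]c3cc(Cl)ccc3c2Cn2ccnc2)cc1`: 261 nM in an assay on isolated protein for inhibition of Aromatase (Homo sapiens), read by ELISA, using NADPH, with a stated time of 24 h; a higher number here means a weaker inhibitor, a lower number a stronger inhibitor
- Compound 2, `Fc1ccc(-c2[nH]c3cc(Cl)ccc3c2Cn2cncn2)cc1`: 96.9 nM in this assay

Compound 2 gives the lowest of the two numbers in this assay. Its nearest neighbour is compound 1, whose number is higher by a margin that lies beyond the usual scatter; no single-point comparison between these two compounds is available, since they differ in more than one place, so only their two values can be set side by side.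

Compound 3, `Clc1ccc(-c2[nH]c3cc(Cl)ccc3c2Cn2cncn2)cc1`, has not yet been measured in this assay. It is reached from compound 2 by one change: chloro in place of fluoro on an aromatic carbon. Compound 1 also carries chloro at this position but has a different five-membered ring on the side chain, so it does not isolate this change. Among the compounds with values here, with no measured step of this kind available, the step from compound 2 to compound 3 is expected to be small, most likely no larger than the scatter, with the direction open. Compound 3 is therefore estimated at 120 nM in this assay, in a range from 45 nM to 320 nM, which corresponds to an expected step of a 1.2-fold higher number from compound 2 to compound 3 (0.09 log units; within the scatter).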

Compound 3, half-maximal inhibitory concentration: 208 nM
For compound 3 the middle estimate is 1.7-fold (0.24 log units) below the measured one, and the stated range covers the measured number.
By their numbers in this assay, from the lowest: compound 2; then compounds 3 and 1 (each within the scatter of the next).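

In this assay, within the data shown here, the move from 4-fluorophenyl to 4-chlorophenyl with the 1H-1,2,4-triazol-1-yl side chain held fixed gives the first clean reading at this position (a 2.1-fold higher number from compound 2 to compound 3 (0.33 log units; beyond the scatter)), a modest step that lies beyond the scatter, so this position does respond to the exchange of fluoro for chloro. Among these compounds, compound 3 also isolates the five-membered ring on the side chain for the first time: 1H-1,2,4-triazol-1-yl in place of 1H-imidazol-1-yl gives a step within the scatter (a 1.3-fold lower number from compound 1 to compound 3 (0.10 log units; within the scatter)), so with chloro on the aromatic ring the two side-chain rings cannot be told apart here. Nothing measured alongside these numbers bears on why either step has the size it has.

From the compounds shown here alone, it remains open whether the step from fluoro to chloro would keep its size with 1H-imidazol-1-yl on the side chain, and whether the two rings would still match with fluoro on the aromatic carbon. Also open, going by these compounds, is how this position would answer to a bromo, methoxy or nitrile group in place of the halogens seen so far.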